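Trading a Methoxy End for an Aromatic Ring

This account rests on a few compounds, and the source may have more. Where it says the series, first, only, none or still open, it means among the compounds named here.

Among the compounds with values here, in a functional assay on a cell-free system (plasma, Homo sapiens) for inhibition, with Plasma (Rattus norvegicus) as the target (on this read-out higher numbers stand for weaker inhibition and lower numbers for stronger inhibition), compound 2 (`COCOc1ccc2c(N3CCNCC3)cc(=O)oc2c1C`) gives 3500 nM as the higher of the two numbers so far, and compound 1 (`Cc1c(OCc2ccccc2)ccc2c(N3CCNCC3)cc(=O)oc12`) gives 1100 nM as the lower. Compound 3 (`Cc1c(OCCOc2ccccc2)ccc2c(N3CCNCC3)cc(=O)oc12`) has phenoxymethyl in place of methoxy on a saturated chain carbon bound to an oxygen on an aromatic ring. Within the data shown here, the one measured step that bears on this is a 3.2-fold higher number from compound 1 to compound 2 (0.50 log units; beyond the scatter) where methoxy replaces phenyl. Compound 3 regains an aromatic ring, so a step of similar size in reverse is expected. The expected change, toward a lower number in this assay, is a 2.7-fold lower number from compound 2 to compound 3 (0.43 log units; beyond the scatter) by this estimate. For compound 3 the estimated value is 1300 nM within an expected range from 450 nM to 3500 nM overall.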

Compound 3, half-maximal inhibitory concentration: 14300 nM
Compound 3: the middle estimate sits 11-fold (1.04 log units) below what was measured, and the stated range ends below it.
By their numbers in this assay, from the lowest: compound 1; then compound 2; then compound 3.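

Adding an aromatic ring at this position does not by itself strengthen inhibition: in this assay phenoxymethyl in place of methoxy gives a 4.1-fold higher number from compound 2 to compound 3 (0.61 log units; beyond the scatter) and so runs against the earlier step. Phenoxymethyl in place of phenyl gives a 13-fold higher number from compound 1 to compound 3 (1.11 log units; beyond the scatter) in the same read-out, so the outcome depends on how the ring is attached, not just on its presence. Nothing measured here explains this difference. Going by these compounds, it remains open whether the added chain length or the added oxygen in phenoxymethyl accounts for the weaker inhibition. An amine or a carboxylic acid at the end of this chain also remains untested in the compounds shown.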